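The source may report more compounds than this note shows. Statements on the series, on what has been measured and on what is new or still open speak of the compounds shown alone.

Measured in a functional assay on FM3A cells (Mus musculus) for inhibition; on this read-out lower numbers stand for stronger inhibition and higher numbers for weaker inhibition:
- compound 1 `O=C1O/C(=C\Cn2ccc(=O)[nH]c2=O)C(OCc2ccccc2)=C1OCc1ccccc1`: 17700 nM
- compound 2 `O=C1O/C(=C\Cn2cnc3c(-n4cccc4)ncnc32)C(OCc2ccccc2)=C1OCc1ccccc1`: > 200000 nM (a limit of the assay)

Among the measured compounds shown here, compound 1 holds the only true number in this assay, so it has no numeric neighbour to rank against. Next comes compound 3 `O=C1O/C(=C\Cn2cc(F)c(=O)[nH]c2=O)C(OCc2ccccc2)=C1OCc1ccccc1`, made from compound 1 by fluoro in place of hydrogen on an aromatic carbon. For the measured compounds named here, no measured step sizes this change. A clear move toward stronger inhibition in this assay is nevertheless expected, and the estimated change is a 7.1-fold lower number from compound 1 to compound 3 (0.85 log units; beyond the scatter). For compound 3 the expected value is 2500 nM, with an estimated range of 400 nM to 18000 nM.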

Compound 3, half-maximal inhibitory concentration: 3400 nM
Compound 3: the middle estimate sits 1.4-fold (0.13 log units) below what was measured; low and high end bracket the measured number.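

In this assay, fluoro in place of hydrogen on the aromatic carbon two atoms from the ring nitrogen gives a 5.2-fold lower number from compound 1 to compound 3 (0.72 log units; beyond the scatter). Among the compounds shown here, this is the first measured size for any change at this position, and it shows that the position accepts a fluorine atom with a gain in inhibition. No measured property shown here bears on why the step arises. From the compounds shown here alone, whether chloro, methyl or an amine on this same carbon moves the number in the same direction stays open. So does whether the gain from fluoro depends on the rest of compound 3.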